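Acyl variation on a shared bicyclic amine core

A few compounds are considered here, and "the series" means these few. Any claim that something is new, unique, unknown or untested is made for them only; others in the source may bear on it.

Measured so far in an assay on SH-EP1 cells for agonist activity at Neuronal acetylcholine receptor; alpha4/beta2 (Homo sapiens), read by FLIPR and calcium flux; a higher number here means that more compound is needed for the effect, a lower number that less compound is needed:
compound 1 `CC(=O)N1CC2CC(C1)N2`, 5100 nM
compound 2 `O=C(C1CCC1)N1CC2CC(C1)N2`, 2900 nM
compound 3 `O=C(C1CCCC1)N1CC2CC(C1)N2`, 11000 nM

Compound 2 carries the lowest of the three numbers, but compound 1 sits within the scatter of it, so the two cannot be ranked against each other; only compound 3 stands clearly apart, its value lying beyond the scatter above compound 2. Among the measured compounds shown here, the one measured step in this assay, a 1.8-fold lower number from compound 1 to compound 2 (0.25 log units; within the scatter), shows that going from a methyl to a four-membered ring on the carbonyl carbon moved the number by less than the scatter. The values of compound 2 and compound 3 show that the larger five-membered ring gave a clearly higher number.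

Compound 4 `O=C([C@@H]1C[C@H]1F)N1CC2CC(C1)N2` differs from compound 2 by 2-fluorocyclopropyl in place of cyclobutyl on a carbonyl carbon. For the measured compounds named here, no measured step covers a fluorine or a three-membered ring, so the expectation rests only on the size of the ring changes already seen: small in one direction, larger in the other. The ring shrinks here, away from the worsening seen in compound 3, and the number for compound 4 is estimated at 3500 nM, within 1200 nM to 10000 nM. The step of a 1.2-fold higher number from compound 2 to compound 4 (0.08 log units; within the scatter) is expected to stay within the scatter.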

Compound 4, half-maximal effective concentration: 120 nM
Estimate against measurement, compound 4: 29-fold (1.46 log units) above; the measured number lies below the stated range.
By their numbers in this assay, from the lowest: compound 4; then compounds 2 and 1 (each within the scatter of the next); then compound 3.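

Among the compounds shown here, the acyl position on the amide-type nitrogen in a ring proves far more responsive in this assay than the earlier compounds suggested: the change to 2-fluorocyclopropyl gives large steps (a 24-fold lower number from compound 2 to compound 4 (1.38 log units; beyond the scatter)) and (a 43-fold lower number from compound 1 to compound 4 (1.63 log units; beyond the scatter)), whereas the change from methyl to cyclobutyl stayed within the scatter (a 1.8-fold lower number from compound 1 to compound 2 (0.25 log units; within the scatter)). The step from cyclobutyl to 2-fluorocyclopropyl leaves the heavy-atom count and the hydrogen-bond donor and acceptor counts unchanged, so these counts do not track the number here; what changes is the ring size, the entry of fluorine and the presence of two defined stereocentres. No supporting data accompany the result, so the change remains unexplained, and its share among those three features cannot be assigned.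

The compounds shown leave open whether plain cyclopropyl on the same carbonyl carbon would already give a number close to that of compound 4, or whether the fluorine is required. Also open, going by these compounds, are the other stereoisomers of 2-fluorocyclopropyl, and whether 2,2-difluorocyclopropyl or 2-methylcyclopropyl would keep the same low number in this assay on the shared core.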